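A Shifted Indole on the Shared Core

The compounds below may be only part of what the source reports. "The series", "measured", "known", "first", "only" and "open" are said of these compounds alone.

Compound 1 `COc1cc(-c2ccnc3cc(-c4ccc(C)cc4)nn23)cc(OC)c1OC`: 21 nM
Compound 2 `COc1cc(-c2ccnc3cc(-c4ccc(C(C)(C)C)cc4)nn23)cc(OC)c1OC`: > 10000 nM, a limit of the assay
Compound 3 `COc1cc(-c2ccnc3cc(-c4c[nH]c5ccccc45)nn23)cc(OC)c1OC`: 40 nM

In a functional assay on B16-F0 cells (Mus musculus) for inhibition, read by CCK-8 assay, with a stated time of 48 h (a lower number here means a stronger inhibitor, a higher number a weaker inhibitor), compound 3 gives 40 nM, the higher of the two numbers measured, its nearest neighbour being compound 1 at a 1.9-fold higher number from compound 1 to compound 3 (0.28 log units; within the scatter). Compound 2 sits at a limit, (the limit of > 10000 nM in this assay, at which 1 of the 3 values shown sits). Compound 4 `COc1cc(-c2ccnc3cc(-c4ccc5ccn(C)c5c4)nn23)cc(OC)c1OC` differs from compound 3 by 1-methyl-1H-indol-6-yl in place of 1H-indol-3-yl on an aromatic carbon. Among the compounds with values here, two measured steps bear on it: a 1.9-fold higher number from compound 1 to compound 3 (0.28 log units; within the scatter) shows that exchanging the aryl group for an indole stays within the scatter, whereas an at least 470-fold higher number from compound 1 to compound 2 (2.67 log units; beyond the scatter) shows that adding carbon on the aryl group can raise the number sharply; an at least 250-fold lower number from compound 2 to compound 3 (2.39 log units; beyond the scatter) is its mirror. A modest rise is therefore expected. Compound 4 is expected to give 100 nM, estimated between 25 nM and 1000 nM. This corresponds to an expected 2.5-fold higher number from compound 3 to compound 4 (0.40 log units; beyond the scatter).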

Compound 4, half-maximal inhibitory concentration: 657 nM
For compound 4 the middle estimate is 6.6-fold (0.82 log units) below the measured one, and the stated range covers the measured number.
By their numbers in this assay, from the lowest: compounds 1 and 3 (each within the scatter of the next); then compound 4. At a limit, above all of these: compound 2.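

In this assay an indole is not freely exchangeable at this position: 1H-indol-3-yl had stayed level with 4-methylphenyl, but 1-methyl-1H-indol-6-yl gives a 16-fold higher number from compound 3 to compound 4 (1.22 log units; beyond the scatter) and a 31-fold higher number from compound 1 to compound 4 (1.50 log units; beyond the scatter). Even so, it does not fall as far as 4-(tert-butyl)phenyl, as an at least 15-fold lower number from compound 2 to compound 4 (1.18 log units; beyond the scatter) shows. That comparison rests on a limit for compound 2: the limit of > 10000 nM in this assay, at which 1 of the 4 values shown sits.

The step changes the indole's attachment point and adds the N-methyl group together, so the compounds shown cannot separate the two. Also open, on these data alone, is how 1H-indol-6-yl or 1-methyl-1H-indol-3-yl would behave here.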